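The source may report more compounds than this note shows. Statements on the series, on what has been measured and on what is new or still open speak of the compounds shown alone.

Compound 1 `COc1cc2c(cc1N1CCN(C)CC1)N(C(=O)c1ccc(-c3cccc(C)n3)c3ccccc13)CC2` gives 2 nM in an assay on isolated protein for binding affinity to 5-hydroxytryptamine receptor 1B (Homo sapiens); on this read-out higher numbers stand for weaker inhibition and lower numbers for stronger inhibition.
Compound 2 `COc1cc2c(cc1N1C[C@@H](C)N[C@@H](C)C1)N(C(=O)c1ccc(-c3ccc(N4CCCC4=O)nc3C)cc1)CC2` gives 5.01 nM in this assay.
Compound 3 `COc1cc2c(cc1N1C[C@@H](C)N(C)[C@@H](C)C1)N(C(=O)Nc1cccc(C(F)(F)F)c1F)CC2` gives 3.98 nM in this assay.

Among these three numbers compound 1 has the lowest one. Its nearest neighbour is compound 3, whose value lies within the scatter of that of compound 1, so the two cannot be told apart. Compound 2 stands furthest away, with a number beyond the scatter above that of compound 1. Among the compounds with values here, no two of the measured compounds differ in only one place, so no single-point step between them is available.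

Compound 4 `CCN1[C@H](C)CN(c2cc3c(cc2OC)CCN3C(=O)c2ccc(-c3cccc(C)n3)c3ccccc23)C[C@@H]1C` has not yet been measured. It differs from compound 1 in one place: 4-ethyl-3,5-dimethylpiperazin-1-yl in place of 4-methylpiperazin-1-yl on an aromatic carbon. The rest of the shared core, the amide and the aryl substituent are kept unchanged.

The three measured compounds carry different piperazine substituents on the same aromatic carbon and still sit within a narrow band, and the expected step from compound 1 to compound 4 is therefore a 1.5-fold higher number from compound 1 to compound 4 (0.18 log units; within the scatter), which is none beyond the scatter. For compound 4 the estimated value in this assay is 3 nM, with a range from 1 nM to 10 nM.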

Compound 4, inhibition constant: 3.98 nM
Compound 4: middle estimate off by 1.3-fold (0.12 log units), on the low side, within the range that was stated.
By their numbers in this assay, from the lowest: compounds 1, 3, 4 and 2 (each within the scatter of the next, the first and the last beyond it).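

Within the data shown here, this is the first comparison that differs in one place, and it gives a direct reading of the position on an aromatic carbon ortho to a methoxy group. In this assay, putting 4-ethyl-3,5-dimethylpiperazin-1-yl in place of 4-methylpiperazin-1-yl gives a 2.0-fold higher number from compound 1 to compound 4 (0.30 log units; within the scatter), so the two compounds cannot be told apart, even though the entering group adds an ethyl group, two further methyl groups and 2 defined stereocentres. Nothing shown here accounts for this outcome, and no cause can be given for it.

Going by these compounds, the ethyl group and the two ring methyl groups enter together, so the contribution of each to this result remains open, as does the role of the defined stereocentres. On these data alone, it also remains open whether this position would hold its affinity with a ring lacking the second nitrogen, such as morpholin-4-yl or piperidin-1-yl, or with a longer chain such as an n-butyl group on the piperazine nitrogen.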